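A chloro group on the benzamide ring of compound 2

The source may report more compounds than this note shows. Statements on the series, on what has been measured and on what is new or still open speak of the compounds shown alone.

Among the compounds with values here, compound 2 `CC(=O)N[C@H]1[C@H]([C@@H](O)[C@H](O)CNC(=O)c2ccccc2)O[C@@](O[C@H]2[C@@H](O)[C@@H](CO)O[C@@H](O[C@@H]3CCO[C@H](COc4ccc(-c5ccccc5)cc4)[C@@H]3O)[C@@H]2O)(C(=O)O)C[C@@H]1O` gives the lower of the two numbers so far measured in an assay on CHO cells for binding affinity to myelin-associated glycoprotein (Homo sapiens), read by surface plasmon resonance (on this read-out higher numbers stand for a longer-lived compound and lower numbers for a shorter-lived compound), namely 0.000186 h; compound 1 `CC(=O)N[C@H]1[C@H]([C@@H](O)[C@H](O)CNC(=O)c2ccccc2)O[C@@](O[C@H]2[C@@H](O)[C@@H](CO)O[C@@H](O[C@H]3[C@@H](O)[C@@H](CO)O[C@@H](OCC[Si](C)(C)C)[C@@H]3O)[C@@H]2O)(C(=O)O)C[C@@H]1O` gives 0.000639 h, a gap beyond the usual scatter. Compound 3 `CC(=O)N[C@H]1[C@H]([C@@H](O)[C@H](O)CNC(=O)c2ccc(Cl)cc2)O[C@@](O[C@H]2[C@@H](O)[C@@H](CO)O[C@@H](O[C@@H]3CCO[C@H](COc4ccc(-c5ccccc5)cc4)[C@@H]3O)[C@@H]2O)(C(=O)O)C[C@@H]1O` differs from compound 2 by chloro in place of hydrogen on an aromatic carbon. Within the data shown here, no measured pair shows this change, so only the change itself guides the expectation. Compound 3 is expected to give 0.00022 h in this assay, between 0.00009 h and 0.0006 h. The step of a 1.2-fold higher number from compound 2 to compound 3 (0.07 log units; within the scatter) is accordingly expected to stay within the usual scatter, with no clear direction.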

Compound 3, half-life: 0.000242 h
Compound 3: middle estimate off by 1.1-fold (0.04 log units), on the low side; measured number inside the range.
By their numbers in this assay, from the lowest: compounds 2 and 3 (each within the scatter of the next); then compound 1.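

In this assay chloro in place of hydrogen on an aromatic carbon, para to a large group, gives a 1.3-fold higher number from compound 2 to compound 3 (0.11 log units; within the scatter) and so leaves the half-life within the usual scatter. This position on the benzamide ring therefore takes a chloro group without a step beyond the scatter, at least on the background of compound 2. Nothing in the data bears on the reason for this result. From the compounds shown here alone, whether an amine, a carboxylic acid or a longer chain at this position would do the same remains open, as does whether chloro behaves alike on the background of compound 1.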